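The compounds below may be only part of what the source reports. "The series", "measured", "known", "first", "only" and "open" are said of these compounds alone.

Measured in a functional assay on the whole organism (strain Wistar) with Rattus norvegicus as the target, read by paw edema; on this read-out lower numbers stand for an effect already at smaller amounts and higher numbers for an effect only at larger amounts of compound:
- Compound 1 `CCC(=O)OCc1cc(-n2nc(C(F)(F)F)cc2-c2ccc(Br)cc2)ccc1S(N)(=O)=O`: 17 mg/kg
- Compound 2 `CCC(=O)NS(=O)(=O)c1ccc(-n2nc(C(F)(F)F)cc2-c2ccc(Br)cc2)cc1COC(=O)CC`: 12.5 mg/kg

Compound 2, at 12.5 mg/kg, has only compound 1 for comparison, and the two lie within the scatter of each other. Compound 3 `CCC(=O)NS(=O)(=O)c1ccc(-n2nc(C(F)(F)F)cc2-c2ccc(Br)cc2)cc1CO` follows from compound 2 by hydrogen in place of propanoyl on an oxygen on a saturated carbon, turning (propanoyloxy)methyl into hydroxymethyl. Among the measured compounds shown here, no measured step covers this oxygen. For the measured compounds named here, the one available step, a 1.4-fold lower number from compound 1 to compound 2 (0.13 log units; within the scatter), concerns a sulfonamide nitrogen, so it bears only loosely on the change. No change beyond the scatter in this assay is therefore expected, and the estimated step is a 1.1-fold higher number from compound 2 to compound 3 (0.05 log units; within the scatter). For compound 3 the estimated value is 14 mg/kg, with an expected range of 6 mg/kg to 32 mg/kg.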

Compound 3, dose for half-maximal effect: 7.2 mg/kg
Beside the measured number, compound 3's estimate is 1.9-fold (0.29 log units) above it; low and high end bracket the measured number.
By their numbers in this assay, from the lowest: compounds 3, 2 and 1 (each within the scatter of the next, the first and the last beyond it).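

In this assay, hydrogen in place of propanoyl on this oxygen, turning (propanoyloxy)methyl into hydroxymethyl, gives a 1.7-fold lower number from compound 2 to compound 3 (0.24 log units; within the scatter). Among the compounds shown here, this is the first measured step at this oxygen, and it shows that the propanoyl ester is not needed for compound 3 to stay level with compound 2. No measured evidence bears on this result. Open, going by these compounds, is whether a methyl ether, an amine or a carboxylic acid at this place would read the same. Also open, on these data alone, is whether hydroxymethyl behaves alike with an unsubstituted sulfonamide nitrogen.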